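A few compounds are considered here, and "the series" means these few. Any claim that something is new, unique, unknown or untested is made for them only; others in the source may bear on it.

Among the measured compounds shown here, in an assay on isolated protein for antagonist activity at Bile acid receptor (Homo sapiens), read by TR-FRET, with a stated time of 20 min (on this read-out lower numbers stand for stronger inhibition and higher numbers for weaker inhibition), compound 2 `Cc1ccc(-c2nn(Cc3ccc4ccccc4c3)cc2C(=O)Nc2ccc(C)c(S(=O)(=O)N3CCOCC3)c2)cc1` gives 10.2 nM, the lowest of the two numbers so far. Its nearest neighbour is compound 1 `Cc1ccc(-c2nn(-c3ccc(Cl)cc3Cl)cc2C(=O)Nc2ccc(C)c(S(=O)(=O)N3CCOCC3)c2)cc1`, which in this assay gives 14.1 nM; the step of a 1.4-fold lower number from compound 1 to compound 2 (0.14 log units; within the scatter) lies within the usual scatter, so the two compounds cannot be told apart on these numbers. Compound 3 `Cc1ccc(-c2nn(CC3CC3)cc2C(=O)Nc2ccc(C)c(S(=O)(=O)N3CCOCC3)c2)cc1` differs from compound 2 by cyclopropyl in place of naphthalen-2-yl on a saturated chain carbon bound to an aromatic nitrogen. For the measured compounds named here, only one measured step bears on this change: a 1.4-fold lower number from compound 1 to compound 2 (0.14 log units; within the scatter), where one aromatic group on the aromatic nitrogen gave way to another and the number hardly moved. Going by the values given here, no measured step removes every aromatic ring from this position, as the move to cyclopropyl does, so the guidance is thin. A somewhat higher number is expected for compound 3, estimated at 35 nM with a range from 8 nM to 200 nM. This expected step for compound 3 is a 3.4-fold higher number from compound 2 to compound 3 (0.54 log units; beyond the scatter).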

Compound 3, half-maximal inhibitory concentration: 76.9 nM
The estimate for compound 3 lay 2.2-fold (0.34 log units) below the measured number, and the stated range covers the measured number.
By their numbers in this assay, from the lowest: compounds 2 and 1 (each within the scatter of the next); then compound 3.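

Among the compounds shown here, putting cyclopropyl in place of naphthalen-2-yl on the saturated chain carbon bound to an aromatic nitrogen gives a 7.5-fold higher number from compound 2 to compound 3 (0.88 log units; beyond the scatter), the first step at this position that lies beyond the scatter. The other comparison points the same way, with cyclopropylmethyl in place of 2,4-dichlorophenyl on the aromatic nitrogen giving a 5.5-fold higher number from compound 1 to compound 3 (0.74 log units; beyond the scatter). So this position is not indifferent to what it carries: the two groups with aromatic rings could not be told apart, yet both give lower numbers than cyclopropylmethyl, though the steps are modest.

Nothing available explains this rise. Cyclopropylmethyl both removes the aromatic rings and reduces the heavy atoms, so these two changes remain tangled, and a benzyl or cyclohexylmethyl group on the aromatic nitrogen could help pull them apart.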